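From methyl to fluoro on an aromatic carbon

The source may hold more compounds than are shown below. What is called first, only, known or untested is meant among the compounds shown, and "the series" means these compounds.

In a functional assay on M14 cells (Homo sapiens) for cytotoxicity (a higher number here means a weaker inhibitor of growth, a lower number a stronger inhibitor of growth), compound 1 `COc1ccc(C2=C(c3ccc(SC)cc3)CC3CCCN3C2=O)cc1C` gives 200 nM and compound 2 `CSc1ccc(C2=C(c3ccc(C)c(C)c3)C(=O)N3CCCC3C2)cc1` gives 800 nM as the higher of the two numbers, which makes it the weaker growth inhibitor so far. Compound 3 `CSc1ccc(C2=C(c3ccc(F)c(C)c3)C(=O)N3CCCC3C2)cc1` has not yet been measured. It differs from compound 2 in one place fluoro in place of methyl on an aromatic carbon with fluoro in place of methyl on an aromatic carbon, so that 3,4-dimethylphenyl becomes 4-fluoro-3-methylphenyl.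

Among the compounds with values here, only one measured step bears on this change, and it falls on the same carbon. Methyl in place of methoxy gave a 4.0-fold higher number from compound 1 to compound 2 (0.60 log units; beyond the scatter) and this modest step shows that a swap at this carbon can move the number. Within the data shown here, it says nothing about fluoro, though, since no measured compound carries that group. No firm direction can therefore be expected, and a change within the scatter seems most likely. The expected result is a 1.1-fold lower number from compound 2 to compound 3 (0.06 log units; within the scatter) (a small step at most). Compound 3 is estimated at 700 nM (expected range 250 nM to 2000 nM).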

Compound 3, concentration for 50% growth inhibition: 800 nM
The estimate for compound 3 lay 1.1-fold (0.06 log units) below the measured number, and the stated range covers the measured number.
By their numbers in this assay, from the lowest: compound 1; then compounds 2 and 3 (each within the scatter of the next).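

In this assay, fluoro in place of methyl brings no change at the digits printed from compound 2 to compound 3 (within the scatter), so this carbon tolerates the exchange of these two small groups without a detectable shift in growth inhibition. Fluoro in place of methoxy brings a 4.0-fold higher number from compound 1 to compound 3 (0.60 log units; beyond the scatter), matching the size of the earlier step, a 4.0-fold higher number from compound 1 to compound 2 (0.60 log units; beyond the scatter), so among these three compounds the methoxy compound alone stands apart, with the lowest number, and methyl and fluoro cannot be told apart. Nothing measured alongside these numbers explains why methoxy differs from the other two groups.

Going by these compounds, with only methoxy, methyl and fluoro compared on this carbon, it remains open whether the lower number belongs to methoxy alone or would also appear with a group such as ethoxy, hydroxyl or an amine. The methyl group that stays in place in compounds 2 and 3 and the methylthio group shared by all three compounds are also untested here, so the compounds shown cannot say how either would behave if replaced by, for example, chloro or a longer chain.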